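Replacing the 4-(trifluoromethyl)phenyl group on a shared core

The source may report more compounds than this note shows. Statements on the series, on what has been measured and on what is new or still open speak of the compounds shown alone.

In a functional assay on MGC-803 cells (Homo sapiens) for cytotoxicity, read by MTT assay, with a stated time of 72 h (on this read-out lower numbers stand for stronger inhibition and higher numbers for weaker inhibition), three compounds built on one shared core have been measured. Compound 1 `C=C1C(=O)[C@@]23C(=O)OC[C@]4(C(=O)CCC(C)(C)[C@H]4C=O)[C@@H]2CC[C@@H]1[C@H]3OC(C)=O` gives 1660 nM and compound 2 `C=C1C(=O)[C@@]23C(=O)OC[C@]4(C(=O)CCC(C)(C)[C@H]4C=O)[C@@H]2CC[C@@H]1[C@H]3OC(=O)c1ccc(C)cc1` gives 2240 nM, two values within the scatter of each other. Compound 3 `C=C1C(=O)[C@@]23C(=O)OC[C@]4(C(=O)CCC(C)(C)[C@H]4C=O)[C@@H]2CC[C@@H]1[C@H]3OC(=O)c1ccc(C(F)(F)F)cc1` gives 4930 nM, the highest number of the three and the weakest inhibition in this assay.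

Compound 4 `C=C1C(=O)[C@@]23C(=O)OC[C@]4(C(=O)CCC(C)(C)[C@H]4C=O)[C@@H]2CC[C@@H]1[C@H]3OC(=O)c1ccccc1F` has not yet been measured. It differs from compound 3 as follows: 2-fluorophenyl in place of 4-(trifluoromethyl)phenyl on a carbonyl carbon, with 2-fluorophenyl in place of 4-(trifluoromethyl)phenyl on a carbonyl carbon.

Among the measured compounds shown here, three measured steps bear on this change. The first, a 1.3-fold higher number from compound 1 to compound 2 (0.13 log units; within the scatter), shows that a 4-methylphenyl group in place of methyl leaves the number within the scatter. The other two are modest: a 3.0-fold higher number from compound 1 to compound 3 (0.47 log units; beyond the scatter) and a 2.2-fold higher number from compound 2 to compound 3 (0.34 log units; beyond the scatter). Compound 4 keeps an aromatic ring but has no trifluoromethyl group, so it is expected to move back towards compound 2, at 2240 nM. For the measured compounds named here, no measured compound carries a 2-fluorophenyl group, so this expectation remains uncertain.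

The expected change is modest and towards a lower number: a 2.0-fold lower number from compound 3 to compound 4 (0.29 log units; within the scatter). Compound 4 is estimated at 2500 nM, with an expected range from 1100 nM to 5500 nM.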

Compound 4, half-maximal inhibitory concentration: 3940 nM
For compound 4 the middle estimate is 1.6-fold (0.20 log units) below the measured one; the measured number falls inside the stated range.
By their numbers in this assay, from the lowest: compounds 1, 2, 4 and 3 (each within the scatter of the next, the first and the last beyond it).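

Within this assay, 2-fluorophenyl in place of 4-(trifluoromethyl)phenyl on this carbonyl carbon gives a 1.3-fold lower number from compound 3 to compound 4 (0.10 log units; within the scatter), and 2-fluorophenyl in place of 4-methylphenyl gives a 1.8-fold higher number from compound 2 to compound 4 (0.25 log units; within the scatter), so the new group cannot be separated from either of the earlier aryl groups, even though those two stand beyond the scatter of each other. Set against the methyl group, the same position gives a 2.4-fold higher number from compound 1 to compound 4 (0.38 log units; beyond the scatter), which places a second aryl group beyond the scatter of the methyl compound, with compound 3 showing the same and compound 2 going against it by staying within the scatter. Nothing measured here accounts for these differences.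

Going by these compounds, compound 1 gives 1660 nM, and among the four compounds no other group on this carbonyl carbon gives a lower number by more than the scatter, so it remains open whether any replacement can improve on the methyl group. Also open, on these data alone, is how this position responds to groups of a different kind, such as a longer alkyl chain, an aryl ring carrying an amine or a carboxylic acid, or 4-fluorophenyl as a direct partner for compound 4.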